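Bromo in place of methylamino on the shared core

The source may report more compounds than this note shows. Statements on the series, on what has been measured and on what is new or still open speak of the compounds shown alone.

Compound 1 `CNc1nc2cc(Cl)c(Cl)cc2n1COC(CO)CO` is known in a functional assay on KB cells (Homo sapiens) for inhibition (on this read-out higher numbers stand for weaker inhibition and lower numbers for stronger inhibition), only as a limit: compound 1 gives > 100000 nM, a limit of the assay and not a number. Compound 2 `CNc1nc2c(Cl)c(Cl)ccc2n1COC(CO)CO` likewise gives only the limit > 100000 nM. Compound 3 `OCC(CO)OCn1cnc2c(Cl)c(Cl)ccc21` also gives only the limit > 100000 nM. For the measured compounds named here, the one step between measured neighbours, a step that the two limits leave unreadable from compound 2 to compound 3, stays unreadable since both of its ends sit at the limit of > 100000 nM in this assay, at which 3 of the 3 values shown sit. Compound 4 `OCC(CO)OCn1c(Br)nc2cc(Cl)c(Cl)cc21` differs from compound 1 by bromo in place of methylamino on an aromatic carbon. Going by the values given here, no measured step covers this exchange, and the series offers no number away from the limit, so neither direction nor size can be read from what is at hand. Compound 4 is therefore expected to stay near the limit, estimated at 100000 nM, in the range 20000 nM to 300000 nM. The estimated step is a number no higher from compound 1 to compound 4 (the limit leaves the size open).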

Compound 4, half-maximal inhibitory concentration: > 100000 nM
Compound 4: no number, only a limit; the forecaster's own chance of this, stated with the estimate: 70%; the middle value lies on the limit itself.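

The step between compound 1 and compound 4 cannot be read, since both ends are limits and not numbers: the limit of > 100000 nM in this assay, at which 4 of the 4 values shown sit. Whether bromo or methylamino on the shared core alters inhibition remains open, as no compound shown gives a number.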